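This account rests on a few compounds, and the source may have more. Where it says the series, first, only, none or still open, it means among the compounds named here.

Compound 1, `CN(C[C@H]1Cc2c(cccc2N2CCN(C3CC3)CC2)CN1)[C@H]1CCCc2cccnc21`, in an ADME assay on microsomes from liver (Mus musculus) for metabolic stability, read by LC-MS, with a stated time of 10 min; a higher number here means that more of the compound is left, a lower number that less of the compound is left: 7%
Compound 2, `CN(C[C@@H]1Cc2c(cccc2N2CCNCC2)CN1)[C@H]1CCCc2cccnc21`: 54.6%
Compound 3, `CC(C)N(C[C@H]1Cc2c(cccc2N2CCNCC2)CN1)[C@H]1CCCc2cccnc21`: 91%

Compound 1 stands lowest of the three numbers in this assay. Within the data shown here, compound 2 gives 54.6% and compound 3 gives 91%, both well above compound 1, though neither differs from compound 1 in a single place, so no single step can be drawn from them. The unmeasured compound 4, `CN(C[C@H]1Cc2c(cccc2N2CCN3CCC[C@H]3C2)CN1)[C@H]1CCCc2cccnc21`, differs from compound 1 as follows: a group of 9 heavy atoms (7 carbon, 2 nitrogen; one five-membered non-aromatic ring with 1 hetero atom, one six-membered non-aromatic ring with 2 hetero atoms) in place of a group of 9 heavy atoms (7 carbon, 2 nitrogen; one three-membered non-aromatic ring of carbon only, one six-membered non-aromatic ring with 2 hetero atoms), on an aromatic carbon. Among the measured compounds shown here, the two compounds have the same atoms, joined differently, and the 4-cyclopropylpiperazin-1-yl that leaves is the only part of compound 1 absent from compounds 2 and 3, whose values in this assay are far higher than that of compound 1. On that basis a step upward beyond the scatter is expected from compound 1 to compound 4, though not as far as the values of compound 2 or compound 3. The expected step is a number 18 percentage points higher from compound 1 to compound 4 (beyond the scatter). Compound 4 is estimated at 25%, between 5% and 55%.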

Compound 4, percent of the compound remaining: 40.1%
Estimate against measurement, compound 4: 15.1 percentage points below; the range from low to high includes it.
By their numbers in this assay, from the lowest: compound 1; then compound 4; then compound 2; then compound 3.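

With the same atoms on the same aromatic carbon, the replacement of 4-cyclopropylpiperazin-1-yl by the group carrying a five-membered non-aromatic ring gives a number 33.1 percentage points higher from compound 1 to compound 4 (beyond the scatter) in this assay. This shows that, at this position, how the atoms of the group are joined can alter the result by more than the usual scatter, even though the counts of heavy atoms, donors and acceptors stay the same. Nothing measured here gives a reason for the step.

On these data alone, it remains open whether a different group in place of the cyclopropyl on the piperazine, such as an acetyl or an oxetanyl, would give a similar step. Also open, as far as these compounds go, is whether the opposite configuration at the defined stereocentre of the entering group would keep the value seen for compound 4 40.1% in this assay.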